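The source may report more compounds than this note shows. Statements on the series, on what has been measured and on what is new or still open speak of the compounds shown alone.

Measured so far:
Compound 1 `NC(=O)c1cccc(Cn2cc(-c3ccc4cn[nH]c4c3)ccc2=O)c1` gives 388 nM in an assay for inhibition of MAP kinase-interacting serine/threonine-protein kinase 1 (Homo sapiens), read by luminescence and ADP-Glo, with a stated time of 2 h; a lower number here means a stronger inhibitor, a higher number a weaker inhibitor.
Compound 2 `Nc1cccc(Cn2cc(-c3ccc4cn[nH]c4c3)ccc2=O)c1` gives 287 nM in this assay.
Compound 3 `O=c1ccc(-c2ccc3cn[nH]c3c2)cn1Cc1ccccc1` gives 315 nM in this assay.

Compound 3 stands second highest of these three numbers, yet all three lie within the scatter of one another: a 1.2-fold lower number from compound 1 to compound 3 (0.09 log units; within the scatter) and a 1.1-fold higher number from compound 2 to compound 3 (0.04 log units; within the scatter).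

Compound 4 `O=c1ccc(-c2ccc3cn[nH]c3c2)cn1Cc1ccccc1Cl` differs from compound 3 in one place: chloro in place of hydrogen on an aromatic carbon. Among the measured compounds shown here, the steps that bear on it are the earlier swaps on the same benzyl ring, each of which stayed within the scatter: a 1.4-fold lower number from compound 1 to compound 2 (0.13 log units; within the scatter), a 1.2-fold lower number from compound 1 to compound 3 (0.09 log units; within the scatter), a 1.1-fold higher number from compound 2 to compound 3 (0.04 log units; within the scatter). Changing a group on this ring has so far moved nothing beyond the scatter, so no step beyond the scatter is expected in this assay here either. Compound 4 is therefore expected at 300 nM, within a range of 130 nM to 700 nM. The expected step is a 1.1-fold lower number from compound 3 to compound 4 (0.02 log units; within the scatter).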

Compound 4, half-maximal inhibitory concentration: 80 nM
Compound 4: the middle estimate sits 3.8-fold (0.57 log units) above what was measured; measured number below the stated range.
By their numbers in this assay, from the lowest: compound 4; then compounds 2, 3 and 1 (each within the scatter of the next).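

On the benzyl ring, a change can move the number after all: in this assay, 2-chlorobenzyl in place of benzyl gives a 3.9-fold lower number from compound 3 to compound 4 (0.60 log units; beyond the scatter) and so goes beyond the scatter, which no swap among compound 1, compound 2 and compound 3 did. The 2-chlorophenyl group also separates from the 3-aminophenyl group, with a 3.6-fold lower number from compound 2 to compound 4 (0.55 log units; beyond the scatter) as the step. No available evidence accounts for this gain.

Chloro appears here only on a carbon ortho to a large group, so the importance of its place remains open. Going by these compounds, whether fluoro, bromo or methyl on that same carbon would give a similar step also remains open.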